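The compounds below may be only part of what the source reports. "The series", "measured", "known", "first", "only" and "open" are said of these compounds alone.

Measured compounds:
compound 1 `COC(=O)c1nc(-c2ccoc2)n(-c2ccc(F)cc2)n1` gives 91600 nM in a functional assay on NCI-H226 cells (Homo sapiens) for inhibition, read by MTT assay, with a stated time of 72 h; a lower number here means a stronger inhibitor of growth, a higher number a weaker inhibitor of growth;
compound 2 `COC(=O)c1nc(-c2ccoc2)n(-c2ccc(C(F)(F)F)cc2)n1` gives 6010 nM;
compound 3 `CCOC(=O)c1nc(-c2ccc[nH]2)n(-c2ccc(C(F)(F)F)cc2)n1` gives 5610 nM.

Compound 2 and compound 1 differ by fluoro in place of trifluoromethyl on an aromatic carbon, and this change produces a 15-fold higher number from compound 2 to compound 1 (1.18 log units; beyond the scatter). Compound 3 carries a different core; the difference between its core and that of compound 2 is not broken down here. Its value lies close to that of compound 2, within the scatter, so no order between the two is claimed. Compound 4 `CCOC(=O)c1nc(-c2ccc[nH]2)n(-c2ccc(F)cc2)n1` is not yet measured; it differs from compound 3 by fluoro in place of trifluoromethyl on an aromatic carbon, the same change as from compound 2 to compound 1. Resting on that one earlier step, the step is expected to be a 15-fold higher number from compound 3 to compound 4 (1.18 log units; beyond the scatter). Compound 4 is therefore estimated at 85000 nM, expected between 35000 nM and 200000 nM.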

Compound 4, concentration for 50% growth inhibition: 5710 nM
For compound 4 the middle estimate is 15-fold (1.17 log units) above the measured one, outside the stated range (below it).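

In this assay, fluoro in place of trifluoromethyl on an aromatic carbon gives a 1.0-fold higher number from compound 3 to compound 4 (0.01 log units; within the scatter), so on the core of compound 3 the two groups cannot be told apart. The size of this change does not carry from one core to the other: the same change on two cores in this assay, a 15-fold higher number (1.18 log units; beyond the scatter) from compound 2 to compound 1 and a 1.0-fold higher number (0.01 log units; within the scatter) from compound 3 to compound 4, 15-fold (1.18 log units) apart, beyond the scatter of two such steps. This shows that the step seen on one core cannot be assumed on the other, but it does not show which difference between the cores accounts for this, and two pairs set no rule for the wider series.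

The compounds shown leave open how a chloro or methoxy group in place of fluoro or trifluoromethyl would behave on either core. They also leave open what an amide or a carboxylic acid in place of the ester would give.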